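Methoxy in Place of tert-Butyl: An Expected Step

The source may report more compounds than this note shows. Statements on the series, on what has been measured and on what is new or still open speak of the compounds shown alone.

Compound 1 `NS(=O)(=O)NCCC1CCN(c2cc(-c3ccccc3)ncn2)CC1` gives 66500 nM in a functional assay on HT-29 cells (Homo sapiens) for antiproliferative activity, read by sulforhodamine B assay, with a stated time of 48 h; a lower number here means a stronger inhibitor of growth, a higher number a weaker inhibitor of growth.
Compound 2 `CC(C)(C)c1ccc(-c2cc(N3CCC(CCNS(N)(=O)=O)CC3)ncn2)cc1` gives 10300 nM in this assay.

Compound 2 holds the lower of the two numbers. Going by the values given here, the only measured step, a 6.5-fold lower number from compound 1 to compound 2 (0.81 log units; beyond the scatter), is modest yet beyond the scatter. Compound 3 `COc1ccc(-c2cc(N3CCC(CCNS(N)(=O)=O)CC3)ncn2)cc1` differs from compound 2 by methoxy in place of tert-butyl on an aromatic carbon. Among the compounds with values here, with a smaller group replacing the one that lowered the number, compound 3 is expected to move partway back toward compound 1, so a 2.4-fold higher number from compound 2 to compound 3 (0.39 log units; beyond the scatter) is expected in this assay. Compound 3 is estimated at 25000 nM, within 8000 nM to 80000 nM.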

Compound 3, concentration for 50% growth inhibition: 72300 nM
The estimate for compound 3 lay 2.9-fold (0.46 log units) below the measured number; the measured number falls inside the stated range.
By their numbers in this assay, from the lowest: compound 2; then compounds 1 and 3 (each within the scatter of the next).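

Putting methoxy in place of tert-butyl gives a 7.0-fold higher number from compound 2 to compound 3 (0.85 log units; beyond the scatter) in this assay, so the lower number of compound 2 is lost entirely, not partly. Methoxy in place of hydrogen gives a 1.1-fold higher number from compound 1 to compound 3 (0.04 log units; within the scatter), so having a group at this position does not by itself lower the number; of the two groups shown, only tert-butyl does. Nothing measured here bears on why these two groups differ.

On these data alone, whether tert-butyl alone lowers the number remains open. An isopropyl group, an amine or a longer carbon chain at this position would help to show how specific the effect is.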